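The source may hold more compounds than are shown below. What is called first, only, known or untested is meant among the compounds shown, and "the series" means these compounds.

Compounds measured so far:
- compound 1, `C=CC(=O)N1C(=O)CC(c2ccc(OC)cc2)Sc2ccccc21`: 43300 nM
- compound 2, `C=CC(=O)N1C(=O)CC(c2ccc(Br)cc2)Sc2ccccc21`: 51300 nM
- compound 3, `C=CC(=O)N1C(=O)CCSc2ccccc21`: 581000 nM

These three share one core and differ only at a saturated ring carbon. In a functional assay on Raji cells (Homo sapiens) for cytotoxicity, read by CCK-8 assay, with a stated time of 24 h (a lower number here means a stronger inhibitor, a higher number a weaker inhibitor), compound 1 gives the lowest of the three numbers, though compound 2 lies within the scatter of it (a 1.2-fold higher number from compound 1 to compound 2 (0.07 log units; within the scatter)), so the two cannot be ranked. Compound 3 stands far off: a 13-fold higher number from compound 1 to compound 3 (1.13 log units; beyond the scatter) and an 11-fold higher number from compound 2 to compound 3 (1.05 log units; beyond the scatter) show that removing either aryl group and leaving a hydrogen in its place weakens the effect strongly.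

Compound 4, `C=CC(=O)N1C(=O)CC(c2cccs2)Sc2ccccc21`, is not yet measured. It differs from compound 1 in this way: thiophen-2-yl in place of 4-methoxyphenyl on a saturated ring carbon. For the measured compounds named here, the steps that bear on it are those from compound 1 to compound 3 and from compound 2 to compound 3, both large and in the weakening direction; they show that an aromatic ring at this carbon matters, while the step from compound 1 to compound 2 shows that swapping one substituent on that ring barely moves the number. Since thiophen-2-yl keeps an aromatic ring at the same place, a step near to none beyond the scatter is expected, a 1.3-fold higher number from compound 1 to compound 4 (0.10 log units; within the scatter). The estimate for compound 4 in this assay is 55000 nM, within 25000 nM to 120000 nM.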

Compound 4, half-maximal inhibitory concentration: 659000 nM
Compound 4: the middle estimate sits 12-fold (1.08 log units) below what was measured, and the stated range ends below it.
By their numbers in this assay, from the lowest: compounds 1 and 2 (each within the scatter of the next); then compounds 3 and 4 (each within the scatter of the next).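

In this assay an aromatic ring at this saturated ring carbon proves not to be enough: thiophen-2-yl in place of 4-methoxyphenyl gives a large step (a 15-fold higher number from compound 1 to compound 4 (1.18 log units; beyond the scatter)), and thiophen-2-yl in place of 4-bromophenyl gives another (a 13-fold higher number from compound 2 to compound 4 (1.11 log units; beyond the scatter)). Against hydrogen at the same carbon, thiophen-2-yl makes no difference that can be read (a 1.1-fold higher number from compound 3 to compound 4 (0.05 log units; within the scatter)), so compound 4 cannot be told apart from compound 3. Among these compounds, only the two substituted six-membered aromatic rings go with the lower numbers, and nothing available explains why the five-membered ring does not.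

On these data alone, it remains open whether the ring size, the ring sulfur or the missing substituent matters most. An unsubstituted phenyl, a thiophen-3-yl or a furan-2-yl group at this carbon would help separate these possibilities.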